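From 2-carboxyethyl to 1-carboxyethyl on compound 2

The source may hold more compounds than are shown below. What is called first, only, known or untested is meant among the compounds shown, and "the series" means these compounds.

Of the compounds shown here, two have numbers so far in a functional assay on HeLa cells (Homo sapiens) for cytotoxicity, read by MTT assay, with a stated time of 72 h (on this read-out higher numbers stand for weaker inhibition and lower numbers for stronger inhibition), and they are far apart. Compound 1 (`CC(C)(C)C1=CC(=O)C=C(NCC(=O)O)C1=O`) gives 132000 nM as its half-maximal inhibitory concentration. Compound 2 (`CC1=CCC[C@H]2[C@](C)(CC3=CC(=O)C=C(NCCC(=O)O)C3=O)[C@@H](C)CC[C@]12C`) gives 8870 nM as the lower of the two numbers, and the gap between them lies well beyond the usual scatter of repeated measurements. These two compounds differ in more than one place, so their gap says little about any single group.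

Compound 3 (`CC1=CCC[C@H]2[C@](C)(CC3=CC(=O)C=C(N[C@@H](C)C(=O)O)C3=O)[C@@H](C)CC[C@]12C`) has not yet been measured. It has the same atoms as compound 2, joined differently: 1-carboxyethyl in place of 2-carboxyethyl on an amine nitrogen. Among the compounds with values here, no measured pair shows what this kind of swap does, so the expectation starts from compound 2 at 8870 nM as the closest reference. In this assay the expected outcome is no change beyond the scatter, with an estimated step of a 1.1-fold higher number from compound 2 to compound 3 (0.03 log units; within the scatter) and no firm direction. For compound 3 the estimate is 9500 nM with an expected range from 4000 nM to 22000 nM in this cell read-out.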

Compound 3, half-maximal inhibitory concentration: 11700 nM
Estimate against measurement, compound 3: 1.2-fold (0.09 log units) below; measured number inside the range.
By their numbers in this assay, from the lowest: compounds 2 and 3 (each within the scatter of the next); then compound 1.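

In this assay, putting 1-carboxyethyl in place of 2-carboxyethyl on the amine nitrogen gives a 1.3-fold higher number from compound 2 to compound 3 (0.12 log units; within the scatter), so the two compounds cannot be told apart on this read-out. Within the data shown here, this is the first pair that differs at this position alone, and it shows that this rearrangement of the same atoms, which also brings in a defined stereocentre, has no effect that can be detected beyond the usual scatter. Nothing measured here speaks to why the two compounds read alike.

The compounds shown leave open whether a longer chain, an ester or an amide in place of the carboxylic acid, or the opposite arrangement at the new stereocentre would give a clearly different number. Compound 1, at 132000 nM, differs from compound 2 and compound 3 in more than one place, so its gap to them cannot be assigned to any single group.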